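Triazole-linked chromone ethers: benzyl substitution and cytotoxicity

A few compounds are considered here, and "the series" means these few. Any claim that something is new, unique, unknown or untested is made for them only; others in the source may bear on it.

Measured compounds:
Compound 1 `O=c1ccoc2cc(OCc3cn(Cc4ccc(Br)cc4)nn3)ccc12`. In a functional assay on SW480 cells (Homo sapiens) for cytotoxicity, read by MTT assay, with a stated time of 48 h (a lower number here means a stronger inhibitor, a higher number a weaker inhibitor), compound 1 gives 37500 nM.
Compound 2 `CC(C)(C)c1ccc(Cn2cc(COc3ccc4c(=O)ccoc4c3)nn2)cc1`. In this assay compound 2 gives 28800 nM.
Compound 3 `O=c1ccoc2cc(OCc3cn(Cc4ccccc4Br)nn3)ccc12`. In this assay compound 3 reaches only a limit of the assay, > 100000 nM.

Compound 3 stands at the weak end of the three: its result is a limit and not a number, as recorded in the limit of > 100000 nM in this assay, at which 1 of the 3 values shown sits. Among the compounds with values here, the step of an at least 2.6-fold higher number from compound 1 to compound 3 (0.42 log units; beyond the scatter) is the only measured step that bears on the bromine's place on the benzyl ring, and it marks a loss beyond the scatter. The step of a 1.3-fold lower number from compound 1 to compound 2 (0.11 log units; within the scatter) shows that exchanging one group for another at the same place on the benzyl ring stays within the scatter.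

Compound 4 `COc1ccc(Cn2cc(COc3ccc4c(=O)ccoc4c3)nn2)cc1` carries 4-methoxyphenyl in place of 2-bromophenyl on a saturated chain carbon bound to an aromatic nitrogen. This change reverses the move seen in the step from compound 1 to compound 3 and at the same time exchanges the group, as in the step from compound 1 to compound 2. A return to the level of compounds 1 and 2 is therefore expected. Compound 4 is estimated to give 35000 nM in this assay, with a range of 15000 nM to 100000 nM. The expected step is an at least 2.8-fold lower number from compound 3 to compound 4 (0.45 log units; beyond the scatter), downward and beyond the scatter.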

Compound 4, half-maximal inhibitory concentration: 20400 nM
Beside the measured number, compound 4's estimate is 1.7-fold (0.23 log units) above it, within the range that was stated.
By their numbers in this assay, from the lowest: compounds 4, 2 and 1 (each within the scatter of the next). At a limit, above all of these: compound 3.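

The change from 2-bromobenzyl to 4-methoxybenzyl gives an at least 4.9-fold lower number from compound 3 to compound 4 (0.69 log units; beyond the scatter) in this assay, the largest step that can be read so far, and it shows that the series regains the level of compound 1 with a group other than bromo or tert-butyl. Methoxy in place of tert-butyl gives a 1.4-fold lower number from compound 2 to compound 4 (0.15 log units; within the scatter), and methoxy in place of bromo gives a 1.8-fold lower number from compound 1 to compound 4 (0.26 log units; within the scatter), so three different groups now read alike in this place, with the hydrogen-bond acceptor that enters with 4-methoxyphenyl leaving no mark beyond the scatter, and only compound 3 stands apart. Compound 3 still has a limit of the assay and not a number, so the true size of its step remains unknown: the limit of > 100000 nM in this assay, at which 1 of the 4 values shown sits.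

From the compounds shown here alone, whether the loss at compound 3 belongs to the place of the group on the benzyl ring or to bromine there remains open, and 2-methoxyphenyl would separate the two. Going by these compounds, how an amine or a carboxylic acid on the benzyl ring would read in this assay is also open, as is whether any benzyl group can move the series clearly away from the level of compounds 1, 2 and 4.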